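A Cyclohexyl Ether Follows Two Open-Chain Ethers

The source may hold more compounds than are shown below. What is called first, only, known or untested is meant among the compounds shown, and "the series" means these compounds.

Two compounds share one core and differ only in the group carried on an oxygen on an aromatic ring. Compound 1 `CCc1sc(CCc2cc(OC(C)C)cc(NCc3cc(Cl)cc(NC(=O)OC(C)C)c3)n2)nc1C` carries an isopropyl group there, and in an assay on cells for binding affinity to Neuropeptide Y receptor type 1 (Homo sapiens) (a lower number here means a stronger inhibitor, a higher number a weaker inhibitor), compound 1 gives 12 nM. Compound 2 `CCc1sc(CCc2cc(OCC(C)(C)C)cc(NCc3cc(Cl)cc(NC(=O)OC(C)C)c3)n2)nc1C` carries a neopentyl group, and in this assay compound 2 gives 55 nM. For the measured compounds named here, that single exchange gave a 4.6-fold higher number from compound 1 to compound 2 (0.66 log units; beyond the scatter), so compound 2 stands with the higher of the two numbers, its only neighbour being compound 1 with the lower one.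

Compound 3 `CCc1sc(CCc2cc(OC3CCCCC3)cc(NCc3cc(Cl)cc(NC(=O)OC(C)C)c3)n2)nc1C` changes the same position again: cyclohexyl in place of neopentyl on an oxygen on an aromatic ring. Going by the values given here, only one measured step touches this oxygen, and it showed that going from the isopropyl group to the neopentyl group weakened binding in this assay by the amount just quoted. A cyclohexyl group is a ring rather than a branched chain, and nothing measured here tells how a ring behaves at this spot. The step of a 1.4-fold lower number from compound 2 to compound 3 (0.14 log units; within the scatter) is therefore expected to stay within the scatter. Compound 3 is estimated at 40 nM, within a range from 12 nM to 150 nM.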

Compound 3, half-maximal inhibitory concentration: 29 nM
Estimate against measurement, compound 3: 1.4-fold (0.14 log units) above; the measured number falls inside the stated range.
By their numbers in this assay, from the lowest: compound 1; then compounds 3 and 2 (each within the scatter of the next).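

Cyclohexyl on this oxygen brings the first ring to the position, and swapping it for the neopentyl chain gives a 1.9-fold lower number from compound 2 to compound 3 (0.28 log units; within the scatter) in this assay, so the two groups cannot be told apart here despite their different shapes. Set against isopropyl, the same ring gives a 2.4-fold higher number from compound 1 to compound 3 (0.38 log units; beyond the scatter) and this modest step lies beyond the scatter, so both neopentyl and cyclohexyl carry higher numbers than isopropyl, and the isopropyl compound 1 keeps the lowest number of the three. Nothing available here explains why isopropyl stands apart or why a ring and a branched chain read alike.

All three groups shown on this oxygen are built from carbon alone, which leaves open how a chain ending in an amine or a hydroxyl group would read in this assay. A smaller ring such as cyclobutyl or cyclopropyl, or a flat phenyl ring, would also test whether the number depends on the ring itself or simply follows the overall size of the group.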